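The source may report more compounds than this note shows. Statements on the series, on what has been measured and on what is new or still open speak of the compounds shown alone.

Working notes on a small set of nucleoside analogues tested for growth inhibition. Compound 1 `C#Cc1cn([C@@H]2O[C@H](CO)[C@@H](O)[C@H]2O)c2ncnc(NC)c12` carries ethynyl together with methylamino. In a functional assay on HCT-116 cells (Homo sapiens), read by MTT assay, with a stated time of 72 h (a lower number here means a stronger inhibitor, a higher number a weaker inhibitor), compound 1 is reported only as a limit of the assay, > 20000 nM. Compound 2 `COc1ncnc2c1c(-c1ccccc1)cn2[C@@H]1O[C@H](CO)[C@@H](O)[C@H]1O` carries phenyl together with methoxy, and in this assay compound 2 likewise stops at a limit, > 20000 nM. Compound 3 `CNc1ncnc2c1c(-c1ccccc1)cn2[C@@H]1O[C@H](CO)[C@@H](O)[C@H]1O` carries phenyl together with methylamino, and in this assay compound 3 is again given only as a limit, > 100000 nM. The change from compound 3 to compound 1, (ethynyl in place of phenyl on an aromatic carbon), gives a step that the two limits leave unreadable from compound 3 to compound 1. The two cores differ by methoxy in place of methylamino on an aromatic carbon, and the corresponding step is a step that the two limits leave unreadable from compound 2 to compound 3. Both steps rest on limits alone, namely the limit of > 100000 nM in this assay, at which 1 of the 3 values shown sits, and (the limit of > 20000 nM in this assay, at which 2 of the 3 values shown sit). Compound 4 `C#Cc1cn([C@@H]2O[C@H](CO)[C@@H](O)[C@H]2O)c2ncnc(OC)c12` is not yet measured; it stands to compound 2 as compound 1 stands to compound 3, the same change, (ethynyl in place of phenyl on an aromatic carbon). The step from compound 2 to compound 4 in this assay is expected to be a step that the limit leaves unreadable from compound 2 to compound 4. That expectation rests on compound 1, whose value is a limit, > 20000 nM. Compound 4 is estimated at 60000 nM, with a range from 20000 nM to 300000 nM, and is most likely to come back as a limit rather than a number.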

Compound 4, half-maximal inhibitory concentration: 5140 nM
Estimate against measurement, compound 4: 12-fold (1.07 log units) above, outside the stated range (below it).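

In this assay, ethynyl in place of phenyl on an aromatic carbon gives an at least 3.8-fold lower number from compound 2 to compound 4 (0.59 log units; beyond the scatter), and with ethynyl held, methoxy in place of methylamino gives an at least 3.8-fold lower number from compound 1 to compound 4 (0.59 log units; beyond the scatter). The same ethynyl-for-phenyl change on the core of compound 3 cannot be read, nor can the methoxy-for-methylamino change with phenyl held, as each of those steps has a limit at both ends, so the change is shown to lower the number on the core of compound 2 but is neither shown to carry over to the core of compound 3 nor shown to fail there. Both readable steps give only a least size, as each starts from a limit: the limit of > 20000 nM in this assay, at which 2 of the 4 values shown sit.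

On these data alone, it remains open whether a nitrile or a longer chain such as propynyl on the same aromatic carbon would keep the number of compound 4. Also open, as far as these compounds go, is how a plain amine or an ethoxy group in place of methoxy would read with ethynyl held.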